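Replacing the oxan-4-yl group of compound 2

The compounds below may be only part of what the source reports. "The series", "measured", "known", "first", "only" and "open" are said of these compounds alone.

In an ADME assay on MT4 cells (Homo sapiens) for cytotoxicity, with a stated time of 5 days (a higher number here means that more compound is tolerated, a lower number that less compound is tolerated), compound 2 (`CC(C)(C)C#Cc1cc(N(C(=O)[C@H]2CC[C@H](C)CC2)[C@H]2CC[C@H](OC3CCOCC3)CC2)c(C(=O)O)s1`) gives 1990 nM and compound 1 (`CC(C)(C)C#Cc1cc(N(C(=O)[C@H]2CC[C@H](C)CC2)[C@H]2CC[C@@H](Oc3ccc(=O)[nH]n3)CC2)c(C(=O)O)s1`) gives 2170 nM. Going by the values given here, these two values lie within the usual scatter of each other, so compound 2 stands level with compound 1 on the only numbers available. Compound 3 (`CC(C)(C)C#Cc1cc(N(C(=O)[C@H]2CC[C@H](C)CC2)[C@H]2CC[C@H](Oc3ccc(=O)[nH]n3)CC2)c(C(=O)O)s1`) has not yet been measured. It departs from compound 2 at one place, on an oxygen on a saturated carbon: a group of 7 heavy atoms (4 carbon, 2 nitrogen, 1 oxygen; one six-membered aromatic ring with 2 hetero atoms) in place of a group of 6 heavy atoms (5 carbon, 1 oxygen; one six-membered non-aromatic ring with 1 hetero atom), on an oxygen on a saturated carbon. Among the compounds with values here, no step between two measured compounds shows directly what such an exchange does. The nearest evidence is compound 1, which also carries the entering group and gives 2170 nM, a value within the scatter of that of compound 2. On that basis, no step beyond the scatter is expected in this assay. The estimated change is a 1.2-fold higher number from compound 2 to compound 3 (0.06 log units; within the scatter). With so little evidence, the expected range is kept wide. For compound 3 the estimated value is 2300 nM, with an expected range from 1100 nM to 5500 nM.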

Compound 3, half-maximal cytotoxic concentration: 1480 nM
Compound 3: the middle estimate sits 1.6-fold (0.19 log units) above what was measured, and the stated range covers the measured number.
By their numbers in this assay, from the lowest: compounds 3, 2 and 1 (each within the scatter of the next).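

In this assay, the exchange of the oxan-4-yl group for the six-membered aromatic ring with 2 hetero atoms, on an oxygen on a saturated carbon, now has a direct step, a 1.3-fold lower number from compound 2 to compound 3 (0.13 log units; within the scatter), where earlier it could only be inferred from compound 1. Going by these compounds alone, the drawn configuration can also be read on its own for the first time, with a 1.5-fold lower number from compound 1 to compound 3 (0.17 log units; within the scatter). Among these three compounds, therefore, neither the group on that oxygen nor the configuration at the two saturated ring carbons shifts the half-maximal cytotoxic concentration beyond the scatter, and the second of these readings is a clean one, with the group held constant: the fact that compounds 1 and 3 differ only in the configuration as drawn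

The compounds shown leave open whether a different kind of group on that oxygen, such as an amine or a carboxylic acid, would give a step beyond the scatter. They also leave open whether the oxan-4-yl group would stay level with the entering group in the configuration that compound 1 carries.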